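Adding a Hydroxyl to an Aromatic Ether Chain

This account rests on a few compounds, and the source may have more. Where it says the series, first, only, none or still open, it means among the compounds named here.

Compound 1 `CCOc1ccc2c(c1)NC(=O)Nc1cnc(C#N)c(n1)OCC/C=C\CO2` was tested in a functional assay on NCI-H1299 cells (Homo sapiens), read by flow cytometry; on this read-out higher numbers stand for an effect only at larger amounts of compound and lower numbers for an effect already at smaller amounts. There compound 1 reached only the assay limit of > 10000 nM. Compound 2 `N#Cc1ncc2nc1OCC/C=C\COc1ccc(CCCO)cc1NC(=O)N2` likewise reached only the assay limit of > 10000 nM. The step that the two limits leave unreadable from compound 1 to compound 2 is therefore not readable, and both values sit at the limit of > 10000 nM in this assay, at which 2 of the 2 values shown sit. Compound 3 `N#Cc1ncc2nc1OCC/C=C\COc1ccc(OCCO)cc1NC(=O)N2` carries the change (hydroxy in place of hydrogen on a saturated chain carbon, two bonds along the chain from an oxygen on an aromatic ring). Among the compounds with values here, no measured step bears on this change, so no direction beyond the scatter is expected, and because of the limit of > 10000 nM in this assay, at which 2 of the 2 values shown sit, compound 3 is expected to stay near that limit. Compound 3 is estimated at 15000 nM, within 4000 nM to 60000 nM. For compound 3 the expected step is a step that the limit leaves unreadable from compound 1 to compound 3.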

Compound 3, half-maximal effective concentration: > 10000 nM
Compound 3 was reported as a limit; the forecaster's own chance of this, stated with the estimate: 85%; the middle value is on the limit's open side.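

In this assay, within the data shown here, compound 3 gives > 10000 nM, which is a limit, so no step from compound 1 or compound 2 to compound 3 can be read. The compounds shown leave open whether any of these changes alters the effect, because all remain at the limit: the limit of > 10000 nM in this assay, at which 3 of the 3 values shown sit.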